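A chlorinated ethenyl swap on the weaker compound

This account rests on a few compounds, and the source may have more. Where it says the series, first, only, none or still open, it means among the compounds named here.

In a functional assay on SK-N-SH cells (Homo sapiens) for cytotoxicity, read by MTT assay, with a stated time of 48 h (a higher number here means a weaker inhibitor, a lower number a stronger inhibitor), compound 1 (`COc1ccc(/C=C/c2cc(OC)c(OC)c(OC)c2-c2ccc(F)c(F)c2)cc1`) gives 6900 nM while compound 2 (`COc1cc(/C=C/c2ccccc2)c(-c2ccccc2)c(OC)c1OC`) gives 63000 nM as the higher number of the two. That makes compound 2 the weaker inhibitor of this pair, by a gap beyond the usual scatter of repeated measurements.

Compound 3 (`C=C(c1ccc(Cl)cc1)c1cc(OC)c(OC)c(OC)c1-c1ccccc1`) has not been measured yet. It differs from compound 2 in one place (1-(4-chlorophenyl)ethenyl in place of 2-phenylethenyl on an aromatic carbon): 1-(4-chlorophenyl)ethenyl in place of 2-phenylethenyl on an aromatic carbon, ortho to a phenyl group. Among the measured compounds shown here, no measured pair of compounds isolates this change, so any forecast is loose. For the measured compounds named here, the only other guide is compound 1 at 6900 nM in the same test, which also carries halogen on an aromatic ring, though it differs from compound 2 in more than one place. A moderate move toward a lower number is therefore expected, with a 3.2-fold lower number from compound 2 to compound 3 (0.50 log units; beyond the scatter) as the estimated step in this assay and no change beyond the scatter still possible. For compound 3 the estimated value is 20000 nM with an expected range from 4000 nM to 80000 nM in this measurement.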

Compound 3, half-maximal inhibitory concentration: 25000 nM
Compound 3: middle estimate off by 1.3-fold (0.10 log units), on the low side; the measured number falls inside the stated range.
By their numbers in this assay, from the lowest: compound 1; then compound 3; then compound 2.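

In this assay, among the compounds shown here, the step of a 2.5-fold lower number from compound 2 to compound 3 (0.40 log units; beyond the scatter) gives the first comparison here that changes only one place. It shows that the group on this aromatic carbon, ortho to a phenyl group, can be exchanged with a modest fall in the number, a fall beyond the usual scatter, so the change from 2-phenylethenyl to 1-(4-chlorophenyl)ethenyl makes a measurable difference, though a small one. Nothing available explains this shift, and the numbers alone cannot give a reason for it.

The exchange does two things at once, adding a chlorine and moving the aromatic ring from carbon 2 to carbon 1 of the ethenyl group, so this single step cannot say which of the two accounts for the lower number, and a 1-phenylethenyl group at the same carbon would be needed to pull them apart. It also leaves open how the number would respond if an amine or a carboxylic acid stood where the chlorine now stands, or if a longer chain replaced the whole ethenyl group.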